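The source may report more compounds than this note shows. Statements on the series, on what has been measured and on what is new or still open speak of the compounds shown alone.

Measured compounds, with the values found in an assay on CHO cells for activation of soluble guanylate cyclase alpha1/beta1 complex (Homo sapiens), read by cGMP accumulation; a higher number here means that more compound is needed for the effect, a lower number that less compound is needed:
compound 1 `CC1(C)C(=O)Nc2nc(-n3nc(CCCC(F)(F)F)c4cc(Cl)ccc43)nc(N)c21` gives 117000 nM.
compound 2 `COC(=O)N(C)c1c(N)nc(-c2nc(Cc3ccccc3F)n3ccccc23)nc1N` gives 20400 nM.
compound 3 `CC1(C)C(=O)Nc2nc(-n3nc(Cc4ccccc4F)c4cc(Cl)ccc43)nc(N)c21` gives 18000 nM.

Compound 3 has the lowest number of the three. Compound 2 sits within the scatter of it, so no order between compound 3 and compound 2 can be read; compound 1 stands clearly higher, the step of a 6.5-fold lower number from compound 1 to compound 3 (0.81 log units; beyond the scatter) being beyond the scatter.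

Compound 4 `CC1(C)C(=O)Nc2nc(-n3nc(CCC(F)(F)F)c4cc(Cl)ccc43)nc(N)c21` is the next change on the core of compound 3: 2,2,2-trifluoroethyl in place of 2-fluorophenyl on a saturated chain carbon bound to an aromatic carbon. For the measured compounds named here, this is the reverse direction of the single step that bears on it: a 6.5-fold lower number from compound 1 to compound 3 (0.81 log units; beyond the scatter), where a fluorinated alkyl chain was replaced by the 2-fluorophenyl group and the number fell. Compound 4 brings back a fluorinated chain, though a shorter one than in compound 1, so a return toward the number of compound 1 is expected, but with wide uncertainty since the chain length differs from anything measured. The expected step is a 4.4-fold higher number from compound 3 to compound 4 (0.65 log units; beyond the scatter), toward a higher number. Compound 4 is therefore estimated at 80000 nM in this assay, with a range from 30000 nM to 250000 nM.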

Compound 4, half-maximal effective concentration: 87000 nM
For compound 4 the middle estimate is 1.1-fold (0.04 log units) below the measured one, within the range that was stated.
By their numbers in this assay, from the lowest: compounds 3 and 2 (each within the scatter of the next); then compounds 4 and 1 (each within the scatter of the next).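

In this assay, 2,2,2-trifluoroethyl in place of 2-fluorophenyl on a saturated chain carbon bound to an aromatic carbon gives a 4.8-fold higher number from compound 3 to compound 4 (0.68 log units; beyond the scatter), so the lower number of compound 3 now stands against two fluorinated chains rather than one. Between those chains, trifluoromethyl in place of 2,2,2-trifluoroethyl on a saturated chain carbon, two bonds along the chain from an aromatic carbon, gives a 1.3-fold lower number from compound 1 to compound 4 (0.13 log units; within the scatter), so no effect of chain length can be read from this pair, and at this place the clear separation in this assay lies between the 2-fluorobenzyl group and the two fluorinated chains. Nothing at hand explains this separation.

Still open, as far as these compounds go, is whether the lower number of compound 3 goes with the aromatic ring or with its fluorine, a question that a plain benzyl group or an unfluorinated propyl chain at this place would address. Also open, from the compounds shown here alone, is how the number responds to a longer trifluoroalkyl chain, or to an amine at the end of the chain.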